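From a Thiazole Amide to a Cyano-Benzothiophene Amide

A few compounds are considered here, and "the series" means these few. Any claim that something is new, unique, unknown or untested is made for them only; others in the source may bear on it.

Compound 1 `O=C(NC1CCN(Cc2ccc(OC3CCNCC3)c(Br)c2)CC1)c1cscn1` is the weakest binder among three close relatives measured in an assay on HEK293 cells for displacement of a labelled ligand from Urotensin-2 receptor (Homo sapiens), read by fluorescence, with a stated time of 90 min (on this read-out lower numbers stand for stronger inhibition and higher numbers for weaker inhibition), where compound 1 gives 970 nM. Compound 2 `O=C(NC1CCN(Cc2ccc(OC3CCNCC3)c(Br)c2)CC1)c1ccccn1`, in which the carbonyl carbon carries a pyridin-2-yl group, gives 120 nM in this assay, and compound 3 `O=C(NC1CCN(Cc2ccc(OC3CCNCC3)c(Br)c2)CC1)c1cc2cc(F)ccc2s1`, with a 5-fluoro-1-benzothiophen-2-yl group there, gives 53 nM. The change from compound 1 to compound 2 brought an 8.1-fold lower number from compound 1 to compound 2 (0.91 log units; beyond the scatter), and the change from compound 1 to compound 3 brought an 18-fold lower number from compound 1 to compound 3 (1.26 log units; beyond the scatter), while the step from compound 2 to compound 3 gave a 2.3-fold lower number from compound 2 to compound 3 (0.35 log units; beyond the scatter).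

Compound 4 `N#Cc1ccc2cc(C(=O)NC3CCN(Cc4ccc(OC5CCNCC5)c(Br)c4)CC3)sc2c1` differs from compound 1 by 6-cyano-1-benzothiophen-2-yl in place of 1,3-thiazol-4-yl on a carbonyl carbon. This resembles the step to compound 3 most closely, since both place a bicyclic benzothiophene on the carbonyl carbon, differing only in the substituent on its six-membered ring; the effect of that substituent is not known from the shown compounds. A large gain is therefore expected, of about a 14-fold lower number from compound 1 to compound 4 (1.14 log units; beyond the scatter), so that compound 4 is estimated at 70 nM in this assay, with a range from 25 nM to 200 nM.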

Compound 4, half-maximal inhibitory concentration: 80 nM
Compound 4: the middle estimate sits 1.1-fold (0.06 log units) below what was measured; the range from low to high includes it.
By their numbers in this assay, from the lowest: compounds 3, 4 and 2 (each within the scatter of the next, the first and the last beyond it); then compound 1.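

A second benzothiophene amide also improves on the thiazole, with a 12-fold lower number from compound 1 to compound 4 (1.08 log units; beyond the scatter) as its step, so the gain seen with compound 3 does not depend on the 5-fluoro group alone. The two benzothiophenes do not separate, since a 1.5-fold higher number from compound 3 to compound 4 (0.18 log units; within the scatter) is within the scatter, and 6-cyano-1-benzothiophen-2-yl is thus tolerated as well as 5-fluoro-1-benzothiophen-2-yl, although group and ring position change together in this step. Compound 4 also stays within the scatter of the pyridine amide, with a 1.5-fold lower number from compound 2 to compound 4 (0.18 log units; within the scatter) as the step, whereas compound 3 lies just beyond it, so the benzothiophene ring alone does not guarantee a clear gain over pyridin-2-yl.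

Nothing shown explains why these groups outperform the thiazole. Still open, going by these compounds, is how an unsubstituted benzothiophene, or one carrying a methoxy group or a carboxylic acid, would compare.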